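A few compounds are considered here, and "the series" means these few. Any claim that something is new, unique, unknown or untested is made for them only; others in the source may bear on it.

Compound 2 `CNCc1nnc(C)n1-c1ccc(Cl)cc1C(=O)c1ccccc1` gives the lower of the two numbers in a functional assay on the whole organism (strain CF-1) for inhibition, with Mus musculus as the target (a higher number here means that more compound is needed for the effect, a lower number that less compound is needed), at 0.1 mg/kg. Compound 1 `Cc1nnc(CN(C)C)n1-c1ccc(Cl)cc1C(=O)c1ccccc1` gives 0.5 mg/kg, and the step of a 5.0-fold lower number from compound 1 to compound 2 (0.70 log units; beyond the scatter) came with hydrogen in place of methyl on an amine nitrogen. Compound 3 `CCNCc1nnc(C)n1-c1ccc(Cl)cc1C(=O)c1ccccc1` carries methyl in place of hydrogen on a saturated chain carbon bound to an amine nitrogen, that is methylamino to ethylamino. Within the data shown here, only the step from compound 1 to compound 2 bears on this, and it concerns the amine nitrogen rather than the chain carbon, so it fixes no direction here. The expected step is a 1.5-fold higher number from compound 2 to compound 3 (0.18 log units; within the scatter), not beyond the scatter. Compound 3 is therefore estimated at 0.15 mg/kg, within 0.05 mg/kg to 0.5 mg/kg.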

Compound 3, dose for half-maximal effect: 0.2 mg/kg
For compound 3 the middle estimate is 1.3-fold (0.12 log units) below the measured one; measured number inside the range.
By their numbers in this assay, from the lowest: compounds 2 and 3 (each within the scatter of the next); then compound 1.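

Ethylamino in place of methylamino gives a 2.0-fold higher number from compound 2 to compound 3 (0.30 log units; within the scatter), so the added methyl on the saturated chain carbon does not separate these two compounds. Ethylamino in place of dimethylamino gives a 2.5-fold lower number from compound 1 to compound 3 (0.40 log units; beyond the scatter), so compound 2 and compound 3, with a single alkyl group on the amine nitrogen, both stand apart from compound 1.

On these data alone, whether propylamino, a free amino group or a cyclic amine such as pyrrolidine in place of ethylamino would stay within this range remains open. Nothing at hand bears on the cause of either step.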